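Chain-end group change from compound 3 to compound 4

The source may hold more compounds than are shown below. What is called first, only, known or untested is meant among the compounds shown, and "the series" means these compounds.

Values in a functional assay on HCT-116 cells (Homo sapiens) for cytotoxicity, read by MTT assay, with a stated time of 72 h (a lower number here means a stronger inhibitor, a higher number a weaker inhibitor), for the measured compounds
- compound 1 `CN(C)CCCCCn1c2c(c3ccccc31)C(=O)c1c[n+]([O-])c3ccccc3c1C2=O` gives 470 nM
- compound 2 `O=C1c2c[n+]([O-])c3ccccc3c2C(=O)c2c1c1ccccc1n2CCCCN1CCNCC1` gives 700 nM
- compound 3 `O=C1c2c[n+]([O-])c3ccccc3c2C(=O)c2c1c1ccccc1n2CCCCN1CCCCC1` gives 200 nM

Compound 3 holds the lowest number of the three, beyond the scatter against both others. The next analogue, compound 4 `CN(C)CCCCn1c2c(c3ccccc31)C(=O)c1c[n+]([O-])c3ccccc3c1C2=O`, has dimethylamino in place of piperidin-1-yl on a saturated chain carbon, four bonds along the chain from an aromatic nitrogen, with dimethylamino in place of piperidin-1-yl on a saturated chain carbon, four bonds along the chain from an aromatic nitrogen as the count of the change. The nearest evidence, a 2.4-fold lower number from compound 1 to compound 3 (0.37 log units; beyond the scatter), read backwards, involves (dimethylamino)methyl rather than dimethylamino, so it bears only in part. At the same place, a 3.5-fold lower number from compound 2 to compound 3 (0.54 log units; beyond the scatter) is also modest. A modest rise is therefore expected in this assay, estimated as a 2.1-fold higher number from compound 3 to compound 4 (0.32 log units; beyond the scatter) and close to the edge of the scatter. Compound 4 is estimated at 420 nM, within an expected range of 200 nM to 900 nM for this measurement.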

Compound 4, half-maximal inhibitory concentration: 450 nM
For compound 4 the middle estimate is 1.1-fold (0.03 log units) below the measured one; the measured number falls inside the stated range.
By their numbers in this assay, from the lowest: compound 3; then compounds 4, 1 and 2 (each within the scatter of the next).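

In this assay, dimethylamino in place of piperidin-1-yl at this chain end gives a modest loss (a 2.3-fold higher number from compound 3 to compound 4 (0.35 log units; beyond the scatter)), so compound 3 now stands apart from a simple acyclic amine as well. Dimethylamino stays within the scatter of piperazin-1-yl (a 1.6-fold lower number from compound 2 to compound 4 (0.19 log units; within the scatter)) and of (dimethylamino)methyl (a 1.0-fold lower number from compound 1 to compound 4 (0.02 log units; within the scatter)), leaving piperidin-1-yl as the only end group that separates from the others. No measurement at hand accounts for these steps.

Open, going by these compounds, is whether another ring amine, such as pyrrolidin-1-yl or morpholin-4-yl, matches piperidin-1-yl. Also open, on these data alone, is how piperidin-1-yl behaves on a shorter or longer chain.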